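The compounds below may be only part of what the source reports. "The series", "measured", "known", "first", "only" and "open" are said of these compounds alone.

Compound 2 `COc1cccc(-c2ccc(C(=O)N(Cc3cccc(OCCCCCC(=O)O)c3)C(C)C)cc2)c1` is known in an ADME assay on HepG2 cells (Homo sapiens) for cytotoxicity, read by CellTiter-Glo and resazurin assay, with a stated time of 72 h (on this read-out lower numbers stand for an effect already at smaller amounts and higher numbers for an effect only at larger amounts of compound), only as a limit: in this assay compound 2 gives > 26000 nM, which is a limit of the assay and not a number. Compound 1 `CC(C)N(Cc1cccc(OCCCCCC(=O)O)c1)C(=O)c1ccc(-c2ccncc2)cc1` is in the same position, since in this assay compound 1 gives > 26000 nM, likewise a limit. The change from compound 1 to compound 2, 3-methoxyphenyl in place of pyridin-4-yl on an aromatic carbon, gives a step that the two limits leave unreadable from compound 1 to compound 2 because both values sit at the limit of > 26000 nM in this assay, at which 2 of the 2 values shown sit. Compound 3 `CC(C)N(Cc1cccc(OCCCCCC(=O)O)c1)C(=O)c1ccc(-c2ccc3c(c2)OCCO3)cc1` differs from compound 2 by 2,3-dihydro-1,4-benzodioxin-6-yl in place of 3-methoxyphenyl on an aromatic carbon. For the measured compounds named here, the only measured step bearing on this position is unreadable, so it offers no direction and no size to carry over. Compound 3 is therefore expected to sit at the limit as well, with a step that the limit leaves unreadable from compound 2 to compound 3 estimated, and an estimate for compound 3 of 30000 nM within a range from 12000 nM to 70000 nM.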

Compound 3, half-maximal effective concentration: > 21900 nM
Compound 3 was reported as a limit (the forecaster's own chance of this, stated with the estimate: 85%); the middle value is on the limit's open side.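

For the compounds shown here, no step among compound 1, compound 2 and compound 3 can be read in this assay: all three values are limits of the assay and not numbers. The compounds shown leave open where the half-maximal effect of each lies, and whether the three groups differ in it at all.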